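Methyl for fluoro on the phenyl amide of compound 3

The compounds below may be only part of what the source reports. "The series", "measured", "known", "first", "only" and "open" are said of these compounds alone.

In a functional assay on BXPC-3 cells (Homo sapiens) for inhibition, read by MTT assay (on this read-out higher numbers stand for weaker inhibition and lower numbers for stronger inhibition), compound 1 `COc1cccc(NC(=O)c2cc3cnc(Nc4ccc(N5CCNCC5)cn4)nc3n2C2CCCC2)c1` gives 10500 nM, compound 2 `COc1ccc(NC(=O)c2cc3cnc(Nc4ccc(N5CCNCC5)cn4)nc3n2C2CCCC2)c(OC)c1` gives 3650 nM and compound 3 `O=C(Nc1ccccc1F)c1cc2cnc(Nc3ccc(N4CCNCC4)cn3)nc2n1C1CCCC1` gives 8370 nM. Compound 3 cannot be separated from compound 1, with a 1.3-fold lower number from compound 1 to compound 3 (0.10 log units; within the scatter), whereas a 2.3-fold higher number from compound 2 to compound 3 (0.36 log units; beyond the scatter) sets it apart from compound 2. Compound 4 `Cc1ccccc1NC(=O)c1cc2cnc(Nc3ccc(N4CCNCC4)cn3)nc2n1C1CCCC1` carries methyl in place of fluoro on an aromatic carbon, ortho to a large group: methyl in place of fluoro on an aromatic carbon. Among the compounds with values here, no measured step makes this exact exchange. The nearest evidence is those two changes on the amide-type nitrogen, which were at most modest, so only a small step of uncertain direction is expected in this assay. The expected change is a 1.1-fold lower number from compound 3 to compound 4 (0.05 log units; within the scatter), within the scatter. For compound 4 the estimated value is 7500 nM, with an expected range from 3500 nM to 15000 nM.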

Compound 4, half-maximal inhibitory concentration: 3340 nM
Estimate against measurement, compound 4: 2.2-fold (0.35 log units) above, and the stated range ends above it.
By their numbers in this assay, from the lowest: compounds 4 and 2 (each within the scatter of the next); then compounds 3 and 1 (each within the scatter of the next).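

In this assay, methyl in place of fluoro on an aromatic carbon, ortho to a large group, gives a 2.5-fold lower number from compound 3 to compound 4 (0.40 log units; beyond the scatter), so exchanging this single heavy atom moves the number beyond the scatter. The 2-methylphenyl amide cannot be separated from the 2,4-dimethoxyphenyl amide, at a 1.1-fold lower number from compound 2 to compound 4 (0.04 log units; within the scatter), but it stands apart from the 3-methoxyphenyl amide, at a 3.1-fold lower number from compound 1 to compound 4 (0.50 log units; beyond the scatter). Nothing shown here gives a reason for the methyl and fluoro difference.

The compounds shown leave open whether chloro or ethyl on this carbon would group with methyl or with fluoro. They also leave open whether an unsubstituted phenyl would match either.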